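The source may hold more compounds than are shown below. What is called first, only, known or untested is meant among the compounds shown, and "the series" means these compounds.

Measured so far:
compound 1 `COc1cccc(CSc2nnc([C@@H](C)c3ccc4cc(OC)ccc4c3)n2-c2ccc(F)cc2)c1`: 14500 nM
compound 2 `COc1ccc2cc([C@H](C)c3nnc(SCc4ccc(Cl)cc4)n3-c3ccc(Cl)cc3)ccc2c1`: 110000 nM
compound 3 `COc1cccc(CSc2nnc([C@@H](C)c3ccc4cc(OC)ccc4c3)n2-c2ccc(Cl)cc2)c1`: 162000 nM

In a functional assay on LNCaP cells (Homo sapiens) for cytotoxicity, read by MTT assay (a higher number here means a weaker inhibitor, a lower number a stronger inhibitor), compound 3 gives the highest of the three numbers. Its nearest neighbour is compound 2, and that gap, a 1.5-fold higher number from compound 2 to compound 3 (0.17 log units; within the scatter), lies within the scatter, so the two cannot be told apart. Its furthest neighbour is compound 1, and that gap, an 11-fold higher number from compound 1 to compound 3 (1.05 log units; beyond the scatter), is large.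

Compound 4 `COc1ccc2cc([C@H](C)c3nnc(SCc4ccc(F)cc4)n3-c3ccc(Cl)cc3)ccc2c1` differs from compound 3 in one place: 4-fluorophenyl in place of 3-methoxyphenyl on a saturated chain carbon bound to a sulfur. Going by the values given here, the one measured step at this same place, a 1.5-fold higher number from compound 2 to compound 3 (0.17 log units; within the scatter), was within the scatter. The large step of an 11-fold higher number from compound 1 to compound 3 (1.05 log units; beyond the scatter) concerns a different ring and does not bear on this change. No step beyond the scatter is therefore expected in this assay for compound 4, in either direction.

Compound 4 is expected to give about 130000 nM in this assay, within a range of 45000 nM to 380000 nM. This estimate means a step of a 1.2-fold lower number from compound 3 to compound 4 (0.10 log units; within the scatter).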

Compound 4, half-maximal inhibitory concentration: 33900 nM
Estimate against measurement, compound 4: 3.8-fold (0.58 log units) above, outside the stated range (below it).
By their numbers in this assay, from the lowest: compound 1; then compound 4; then compounds 2 and 3 (each within the scatter of the next).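

In this assay, going by these compounds alone, the group on the saturated chain carbon bound to a sulfur proves able to move the number: 4-fluorophenyl in place of 3-methoxyphenyl gives a 4.8-fold lower number from compound 3 to compound 4 (0.68 log units; beyond the scatter), whereas the only earlier step at this place stayed within the scatter. Fluoro in place of chloro at the same place gives a 3.2-fold lower number from compound 2 to compound 4 (0.51 log units; beyond the scatter), so the 4-fluorophenyl group separates compound 4 from both compound 2 and compound 3. Chloro in place of fluoro raises the number in both pairs that allow this comparison, but the size of the rise depends on the core: the same change on two cores in this assay, an 11-fold higher number (1.05 log units; beyond the scatter) from compound 1 to compound 3 and a 3.2-fold higher number (0.51 log units; beyond the scatter) from compound 4 to compound 2, 3.4-fold (0.54 log units) apart, beyond the scatter of two such steps.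

The compounds shown cannot tell whether this difference comes from the ring carrying the halogen or from the rest of the core. As far as these compounds go, how an unsubstituted phenyl, a carboxylic acid or an amine would read at this place also remains open.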